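Fluoro for hydrogen on the phenyl in two cores

A few compounds are considered here, and "the series" means these few. Any claim that something is new, unique, unknown or untested is made for them only; others in the source may bear on it.

Compound 1 `C=C1C[C@]23C[C@@]1(O)CC[C@H]2c1cc(Br)c(O)c(C)c1[C@@H]3Cn1cc(-c2ccccc2)nn1` gives only a limit in a functional assay on A549 cells (Homo sapiens) for cytotoxicity, read by MTT assay, with a stated time of 4 days (on this read-out lower numbers stand for stronger inhibition and higher numbers for weaker inhibition), > 20000 nM.
Compound 2 `C=C1C[C@]23C[C@@]1(O)CC[C@H]2c1cc(Br)c(O)c(C)c1[C@@H]3Cn1cc(-c2ccc(F)cc2)nn1` gives 17900 nM in this assay .
Compound 3 `C=C1C[C@]23C[C@@]1(O)CC[C@@H]2c1cccc(C)c1[C@@H]3Cn1cc(-c2ccccc2)nn1` gives only a limit in this assay , > 20000 nM.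

The change from compound 1 to compound 2 is fluoro in place of hydrogen on an aromatic carbon. In this assay it gives an at least 1.1-fold lower number from compound 1 to compound 2 (0.04 log units; that floor lies within the scatter). The size of that step is known only as a floor because of the limit of > 20000 nM in this assay, at which 2 of the 3 values shown sit. Compound 3 carries a different core; the difference between the core of compound 3 and the core of compound 1 is not broken down here.

Compound 4 `C=C1C[C@]23C[C@@]1(O)CC[C@@H]2c1cccc(C)c1[C@@H]3Cn1cc(-c2ccc(F)cc2)nn1` stands to compound 3 as compound 2 stands to compound 1: fluoro in place of hydrogen on an aromatic carbon. The two place descriptions read the same word for word, so this is the same kind of change carried onto the core of compound 3.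

In this assay the expected step is a step that the limit leaves unreadable from compound 3 to compound 4, set beside an at least 1.1-fold lower number from compound 1 to compound 2 (0.04 log units; that floor lies within the scatter), which itself lies within the scatter. This expectation rests on compound 3 sitting at the limit in this assay and on the measured fluoro step showing no size that exceeds the scatter. Compound 4 is therefore expected to give 25000 nM in this assay , with a plausible range from 12000 nM to 60000 nM, and a limit rather than a number is the likelier outcome.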

Compound 4, half-maximal inhibitory concentration: > 20000 nM
Compound 4 ended at the assay's limit (the forecaster's own chance of this, stated with the estimate: 60%); the middle value is on the limit's open side.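

In this assay compound 4 gives > 20000 nM, which is a limit and not a number. Compound 3 sits at a limit as well, so the change from phenyl to 4-fluorophenyl between compound 3 and compound 4 gives no readable step: the limit of > 20000 nM in this assay, at which 3 of the 4 values shown sit.

The compounds shown leave open whether this change has any real size on the core of compound 3, and how that core compares with the core of compound 1.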